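Shortening the hydroxyalkyl side chain on a naphthoquinone

This account rests on a few compounds, and the source may have more. Where it says the series, first, only, none or still open, it means among the compounds named here.

Measured so far:
compound 1, `CC(C)=CC[C@@H](OC[C@@H](C)O)C1=CC(=O)c2c(O)ccc(O)c2C1=O`: 22500 nM in a functional assay on HeLa cells (Homo sapiens) for cytotoxicity, read by MTT assay; a lower number here means a stronger inhibitor, a higher number a weaker inhibitor
compound 2, `CCC(O)CO[C@H](CC=C(C)C)C1=CC(=O)c2c(O)ccc(O)c2C1=O`: 28700 nM in this assay

Compound 2 gives the highest of the two numbers, yet its nearest neighbour compound 1 sits within the scatter of it, so no order can be read between them. Compound 3, `CC(C)=CC[C@@H](OCCO)C1=CC(=O)c2c(O)ccc(O)c2C1=O`, differs from compound 2 in one place: hydrogen in place of ethyl on a saturated chain carbon bound to an oxygen on a saturated carbon and a saturated chain carbon. Within the data shown here, the only measured step that bears on this region is a 1.3-fold higher number from compound 1 to compound 2 (0.11 log units; within the scatter), which altered the same chain and stayed within the scatter. Compound 3 is therefore expected to show a 1.1-fold lower number from compound 2 to compound 3 (0.06 log units; within the scatter), no step beyond the scatter. The estimate for compound 3 is 25000 nM, ranging from 10000 nM to 60000 nM.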

Compound 3, half-maximal inhibitory concentration: 18600 nM
Estimate against measurement, compound 3: 1.3-fold (0.13 log units) above; the measured number falls inside the stated range.
By their numbers in this assay, from the lowest: compounds 3, 1 and 2 (each within the scatter of the next).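

In this assay the bare carbon now gives a direct reading: hydrogen in place of ethyl gives a 1.5-fold lower number from compound 2 to compound 3 (0.19 log units; within the scatter) and hydrogen in place of methyl gives a 1.2-fold lower number from compound 1 to compound 3 (0.08 log units; within the scatter). Hydrogen, methyl and ethyl on this saturated chain carbon therefore cannot be told apart in these three compounds, so removing the group altogether produces no readable change. Nothing available explains this result. From the compounds shown here alone, whether a much longer chain, an amine or a carboxylic acid at this carbon would move the number beyond the scatter remains open.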